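The source may hold more compounds than are shown below. What is called first, only, known or untested is meant among the compounds shown, and "the series" means these compounds.

Of the compounds shown here, three sharing one core have been measured in an ADME assay on CHO cells (Cricetulus griseus) for cytotoxicity, read by MTT assay, with a stated time of 24 h; on this read-out higher numbers stand for weaker inhibition and lower numbers for stronger inhibition. Compound 1 (`CCOS(=O)(=O)/C=C/c1ccc(OCC2=CC[C@@H]3C(C(=O)Nc4ccc(Oc5ccccc5)cc4)=CO[C@@H](OC)[C@H]23)cc1`) gives > 200000 nM, which is a limit of the assay and not a number. Compound 2 (`CCOS(=O)(=O)/C=C/c1ccc(OCC2=CC[C@@H]3C(C(=O)Nc4ccc(Oc5ccc(Br)cc5Cl)cc4)=CO[C@@H](OC)[C@H]23)cc1`) gives > 200000 nM, which is likewise a limit. Within the data shown here, compound 3 (`CCOS(=O)(=O)/C=C/c1ccc(OCC2=CC[C@@H]3C(C(=O)Nc4ccc(Oc5ccccc5)cc4)=CO[C@@H](OCc4ccccc4)[C@H]23)cc1`) gives 62000 nM, the only actual number among the three. The series thus shows an at least 3.2-fold lower number from compound 1 to compound 3 (0.50 log units; beyond the scatter).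

Compound 4 (`CCOS(=O)(=O)/C=C/c1ccc(OCC2=CC[C@@H]3C(C(=O)Nc4ccc(Oc5ccc(Br)cc5Cl)cc4)=CO[C@@H](OCc4ccccc4)[C@H]23)cc1`) has not yet been measured. Its difference from compound 3 is this: 4-bromo-2-chlorophenyl in place of phenyl on an oxygen on an aromatic ring. In plain words, 4-bromo-2-chlorophenyl stands in place of phenyl on an oxygen on an aromatic ring. The same exchange has been measured once, as a step that the two limits leave unreadable from compound 1 to compound 2. That single precedent is of little use, with the limit of > 200000 nM in this assay, at which 2 of the 3 values shown sit. It offers neither a size nor a direction to carry over. Starting from compound 3 at 62000 nM, with no readable size from a step that the two limits leave unreadable from compound 1 to compound 2, no change beyond the scatter is expected in this assay. The estimated step is a 1.1-fold higher number from compound 3 to compound 4 (0.05 log units; within the scatter). A result reported only as a limit remains a real possibility. Compound 4 is expected at 70000 nM, with an estimated range from 25000 nM to 200000 nM.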

Compound 4, half-maximal inhibitory concentration: > 200000 nM
Compound 4: no number, only a limit (the forecaster's own chance of this, stated with the estimate: 35%); middle value at least 2.8-fold (0.45 log units) from the limit.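

In this assay, the change to 4-bromo-2-chlorophenyl in place of phenyl on an oxygen on an aromatic ring now has a direction, giving an at least 3.2-fold higher number from compound 3 to compound 4 (0.50 log units; beyond the scatter) where the earlier pair offered neither a size nor a sign. The size printed for this step is only a minimum, so the true change may be larger. The steps that join compound 1, compound 2 and compound 4 cannot be read, because both ends of each sit at a limit: the limit of > 200000 nM in this assay, at which 3 of the 4 values shown sit.

As far as these compounds go, the lower number that came with phenyl in place of hydrogen on a saturated chain carbon bound to an oxygen on a saturated carbon is therefore readable only with the plain phenoxy group, and whether it also holds with 4-bromo-2-chlorophenoxy stays open. The compounds shown also do not separate the two halogens, so a phenyl carrying chlorine alone or bromine alone, or one carrying an amine or a carboxylic acid, could show whether the rise in number belongs to either halogen or to any substitution on that ring.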